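Benzyl ether analogue in a cytotoxicity series

A few compounds are considered here, and "the series" means these few. Any claim that something is new, unique, unknown or untested is made for them only; others in the source may bear on it.

Measured compounds in a functional assay on KB cells (Homo sapiens) for cytotoxicity, read by MTT assay, with a stated time of 72 h; a higher number here means a weaker inhibitor, a lower number a stronger inhibitor:
Compound 1 `CCCOCNc1n[n+]([O-])c2cc(OC)ccc2[n+]1[O-]` gives 12000 nM.
Compound 2 `COc1ccc2c(c1)[n+]([O-])nc(NCOC(C)c1ccccc1)[n+]2[O-]` gives 12400 nM.
Compound 3 `COCNc1n[n+]([O-])c2ccccc2[n+]1[O-]` gives 9070 nM.

Compound 2 sits with compound 1 and compound 3 within the scatter in this assay; the whole spread over the three numbers is within the scatter, so none of the three can be set apart from the others on the data at hand.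

Compound 4 `COc1ccc2c(c1)[n+]([O-])nc(NCOCc1ccccc1)[n+]2[O-]` is the next compound to be measured. It differs from compound 2 in one place: hydrogen in place of methyl on a saturated chain carbon bound to an aromatic carbon and an oxygen on a saturated carbon. For the measured compounds named here, one measured step bears on this part of the molecule: a 1.0-fold higher number from compound 1 to compound 2 (0.01 log units; within the scatter), an exchange of the whole group on the oxygen on the saturated carbon that left the number unchanged beyond the scatter. Compound 2 and compound 3 differ in more than one place, and their two values also lie within the scatter of each other. Going by the values given here, no measured step touches the saturated chain carbon bound to an aromatic carbon and an oxygen on a saturated carbon directly.

For compound 4 in this assay no step beyond the scatter is therefore expected, a 1.0-fold lower number from compound 2 to compound 4 (0.01 log units; within the scatter). The estimate for compound 4 is 12000 nM, with a range from 6000 nM to 24000 nM.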

Compound 4, half-maximal inhibitory concentration: 18100 nM
For compound 4 the middle estimate is 1.5-fold (0.18 log units) below the measured one, and the stated range covers the measured number.
By their numbers in this assay, from the lowest: compounds 3, 1, 2 and 4 (each within the scatter of the next).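

In this assay, for the compounds shown here, hydrogen in place of methyl on a saturated chain carbon bound to an aromatic carbon and an oxygen on a saturated carbon gives a first direct reading at this position (a 1.5-fold higher number from compound 2 to compound 4 (0.16 log units; within the scatter)), and on these numbers benzyl and 1-phenylethyl cannot be told apart. Phenyl in place of ethyl on a saturated chain carbon bound to an oxygen on a saturated carbon is also read for the first time (a 1.5-fold higher number from compound 1 to compound 4 (0.18 log units; within the scatter)), and this exchange likewise does not separate the two compounds, so neither the methyl nor the phenyl has a measurable effect in this set. No supporting measurement is at hand to explain either step.

As far as these compounds go, whether a longer chain or a hydroxyl group on this carbon, or an amine or a carboxylic acid on the phenyl, would give a step beyond the scatter remains open. Going by these compounds alone, the role of the methoxy group on the shared core also remains open, as compound 3, the only compound without it, differs from the others in more than one place.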